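Swapping bromophenyl for dimethylphenyl: expected cytotoxicity

The source may hold more compounds than are shown below. What is called first, only, known or untested is meant among the compounds shown, and "the series" means these compounds.

Compound 2 `COc1ccc(CSc2nc(Cc3cccc(Br)c3)c(C)c(=O)[nH]2)cc1` was tested in an ADME assay on MT4 cells (Homo sapiens) for cytotoxicity, read by MTT assay (on this read-out lower numbers stand for higher toxicity in this test and higher numbers for lower toxicity in this test), where it gives > 290000 nM, which is a limit of the assay rather than a number. Compound 1 `COc1ccc(CSc2nc(Cc3ccccc3Br)c(C)c(=O)[nH]2)cc1` gives 179000 nM in this assay. Compound 3 `Cc1c(Cc2cccc(Br)c2)nc(SCc2ccc([N+](=O)[O-])cc2)[nH]c1=O` gives only a limit there, > 280000 nM. Going by the values given here, the step of an at least 1.6-fold higher number from compound 1 to compound 2 (0.20 log units; that floor lies within the scatter) is the only measured change at the same place, and a step that the two limits leave unreadable from compound 2 to compound 3 cannot be read from the two limits. Compound 4 `COc1ccc(CSc2nc(Cc3cc(C)cc(C)c3)c(C)c(=O)[nH]2)cc1` differs from compound 2 by 3,5-dimethylphenyl in place of 3-bromophenyl on a saturated chain carbon bound to an aromatic carbon. With no measured change beyond the scatter to lean on, the step of an at least 1.1-fold lower number from compound 2 to compound 4 (0.06 log units; that floor lies within the scatter) is expected to be small or none. Compound 4 is therefore estimated at 250000 nM, within a range from 110000 nM to 550000 nM, and a limit is likely.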

Compound 4, half-maximal cytotoxic concentration: > 329000 nM
Compound 4 gave a limit, no number; the forecaster's own chance of this, stated with the estimate: 60%; at least 1.3-fold (0.11 log units) between middle value and limit.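

Compound 4 gives only a limit in this assay, > 329000 nM. A second substituent pattern at this place, 3,5-dimethylphenyl with no bromine, therefore also yields no number, joining 3-bromophenyl; the change between these two groups cannot be read, as both ends are limits. Going by these compounds alone, the one readable step, an at least 1.8-fold higher number from compound 1 to compound 4 (0.26 log units; that floor lies within the scatter), gives only a floor.

Left open is whether an amine or a carboxylic acid on this aromatic ring would give a real number in this assay rather than a limit.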